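This account rests on a few compounds, and the source may have more. Where it says the series, first, only, none or still open, it means among the compounds named here.

Measured compounds in an ADME assay on cells (Macrophage, Homo sapiens) for inhibition; on this read-out higher numbers stand for lower toxicity in this test and lower numbers for higher toxicity in this test:
- Compound 1, `c1ccc(Cc2nnc(Cn3nnc4ccccc43)o2)cc1`; in this assay compound 1 gives > 100000 nM, which is a limit of the assay and not a number.
- Compound 2, `Brc1ccc(Cc2nnc(Cn3nnc4ccccc43)o2)cc1`; compound 2 gives > 100000 nM, again a limit.
- Compound 3, `COc1ccc(Cc2nnc(Cn3nnc4ccccc43)o2)cc1`; compound 3 gives > 100000 nM, likewise a limit.

Compound 3 therefore stands where the whole series stands so far: at the ceiling of this assay, with no numeric value of its own. The three substituent swaps among the measured compounds give nothing readable: the step from compound 1 to compound 2 is a step that the two limits leave unreadable from compound 1 to compound 2, from compound 1 to compound 3 it is a step that the two limits leave unreadable from compound 1 to compound 3, and from compound 2 to compound 3 it is a step that the two limits leave unreadable from compound 2 to compound 3. Going by the values given here, the only evidence is the limit of > 100000 nM in this assay, at which 3 of the 3 values shown sit.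

Compound 4, `O=[N+]([O-])c1ccc(Cc2nnc(Cn3nnc4ccccc43)o2)cc1`, carries the change (nitro in place of methoxy on an aromatic carbon). Both relevant measured steps, bromo for hydrogen and methoxy for bromo on the same aromatic carbon, bear on this swap, and neither moved the read-out off the limit. The expected step from compound 3 to compound 4 is a step that the limit leaves unreadable from compound 3 to compound 4, most plausibly again unreadable. Compound 4 is therefore expected at about 150000 nM, estimated between 40000 nM and 600000 nM, with the result most likely reported once more as a limit.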

Compound 4, half-maximal cytotoxic concentration: > 100000 nM
Compound 4: a limit, no number; the forecaster's own chance of this, stated with the estimate: 80%; the middle value does not contradict the limit.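

The steps from compound 1, compound 2 and compound 3 to compound 4 cannot be read; each pair sets one limit against another. The compounds shown leave open what numeric value any of them would give, and whether any substituent on this core would yield one: the limit of > 100000 nM in this assay, at which 4 of the 4 values shown sit.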